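Sulfonyl substituent swap in a triazine acylsulfonamide series

The source may hold more compounds than are shown below. What is called first, only, known or untested is meant among the compounds shown, and "the series" means these compounds.

Compound 3 `CC(C)(C)CNCCS(=O)(=O)NC(=O)c1ccc(Nc2nc(NC3(c4ccc(Cl)cc4)CC3)nc(OCC(F)(F)F)n2)cc1` sits second highest of the three compounds measured in an ADME assay on microsomes from liver (Rattus norvegicus) for metabolic stability, with a stated time of 10 min (on this read-out higher numbers stand for a more stable compound and lower numbers for a less stable compound), where compound 3 gives 90%. Going by the values given here, its neighbours lie within the scatter on either side: compound 2 `CC(C)C(=O)NCCS(=O)(=O)NC(=O)c1ccc(Nc2nc(NC3(c4ccc(Cl)cc4)CC3)nc(OCC(F)(F)F)n2)cc1` gives 84%, and compound 1 `CC(C)NCCS(=O)(=O)NC(=O)c1ccc(Nc2nc(NC3(c4ccc(Cl)cc4)CC3)nc(OCC(F)(F)F)n2)cc1` gives 100%; the step of a number 6 percentage points higher from compound 2 to compound 3 (within the scatter) and the step of a number 10 percentage points lower from compound 1 to compound 3 (within the scatter) are both within the scatter, while only the step of a number 16 percentage points lower from compound 1 to compound 2 (beyond the scatter) is beyond it, and modest at that.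

Compound 4 `Cc1ccccc1S(=O)(=O)NC(=O)c1ccc(Nc2nc(NC3(c4ccc(Cl)cc4)CC3)nc(OCC(F)(F)F)n2)cc1` has not yet been measured in this assay. It differs from compound 3 by 2-methylphenyl in place of 2-(neopentylamino)ethyl on a sulfonyl sulfur. Among the compounds with values here, none of the measured steps touches the sulfonyl sulfur; all three vary the group on the amine nitrogen, and two of them stayed within the scatter. Within the data shown here, no measured step therefore bears directly on this change, and the expectation rests only on the narrow spread of the series so far.

On that basis compound 4 is expected to stay high, with an estimated 85% between 60% and 100%. The step from compound 3 is estimated as a number 5 percentage points lower from compound 3 to compound 4 (within the scatter), that is, no change beyond the scatter, with a wider range to reflect the untested position.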

Compound 4, percent of the compound remaining: 100%
Compound 4: the middle estimate sits 15 percentage points below what was measured; low and high end bracket the measured number.
By their numbers in this assay, from the lowest: compounds 2, 3, 1 and 4 (each within the scatter of the next, the first and the last beyond it).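

In this assay, 2-methylphenyl on the sulfonyl sulfur, a carbon-only aromatic ring with no hydrogen-bond donor or acceptor, replaces 2-(neopentylamino)ethyl with a number 10 percentage points higher from compound 3 to compound 4 (within the scatter) and replaces 2-(isopropylamino)ethyl with no change at the digits printed from compound 1 to compound 4 (within the scatter) in the comparison of those two chains. Only the replacement of 2-((isopropylcarbonyl)amino)ethyl goes beyond the scatter, with a number 16 percentage points higher from compound 2 to compound 4 (beyond the scatter) and so a modest step, which means this position accepts an aromatic ring as well as the open chains on this read-out. Nothing measured here accounts for these steps.

Open, as far as these compounds go, is how a plain phenyl, a pyridine ring or a carboxylic acid at the end of the ethyl chain would read on the sulfonyl sulfur. Also open, from the compounds shown here alone, is whether the methyl group of 2-methylphenyl contributes to the result.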